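The source may report more compounds than this note shows. Statements on the series, on what has been measured and on what is new or still open speak of the compounds shown alone.

In an ADME assay on HeLa cells (Homo sapiens) for cytotoxicity, read by MTT assay (a lower number here means a stronger inhibitor, a higher number a weaker inhibitor), compound 1 `COc1ccc(C[C@H]2COC(=O)[C@@H]2Cc2ccc(OCC(=O)N3CCCCC3)c(OC)c2)cc1OC` gives 293000 nM. Compound 2 `COc1ccc(C[C@H]2COC(=O)[C@@H]2Cc2ccc(OC(=O)CCC(=O)N3CCCC3)c(OC)c2)cc1OC` gives 201000 nM, which is a 1.5-fold lower number from compound 1 to compound 2 (0.16 log units; within the scatter). Compound 3 `COc1ccc(C[C@H]2COC(=O)[C@@H]2Cc2ccc(OC(=O)CCC(=O)N3CCCCC3)c(OC)c2)cc1OC` gives 128000 nM, which is a 2.3-fold lower number from compound 1 to compound 3 (0.36 log units; beyond the scatter). Between the last two, the difference is a 1.6-fold lower number from compound 2 to compound 3 (0.20 log units; within the scatter). Compound 1 therefore stands clearly apart only from compound 3.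

Compound 4 `COc1ccc(C[C@H]2COC(=O)[C@@H]2Cc2ccc(OCc3cn(Cc4ccccc4)nn3)c(OC)c2)cc1OC` keeps the core of compound 1 and differs from it as follows: 1-benzyl-1H-1,2,3-triazol-4-yl in place of (piperidin-1-yl)carbonyl on a saturated chain carbon bound to an oxygen on an aromatic ring. An amide-bearing side group gives way to a 1-benzyl-1H-1,2,3-triazol-4-yl group, which brings a second aromatic ring system into the side chain.

Among the measured compounds shown here, none of the measured compounds carries this triazole, so the earlier steps offer only a rough guide. They do show that changing the group on this same oxygen has so far had a limited effect, with the largest change being a 2.3-fold lower number from compound 1 to compound 3 (0.36 log units; beyond the scatter). A small change in this assay is therefore expected, and the estimated step is a 1.5-fold lower number from compound 1 to compound 4 (0.17 log units; within the scatter). The estimated value for compound 4 is 200000 nM, with an expected range of 70000 nM to 500000 nM.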

Compound 4, half-maximal inhibitory concentration: 346000 nM
Beside the measured number, compound 4's estimate is 1.7-fold (0.24 log units) below it; measured number inside the range.
By their numbers in this assay, from the lowest: compounds 3, 2, 1 and 4 (each within the scatter of the next, the first and the last beyond it).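

In this assay, the exchange of (piperidin-1-yl)carbonyl for 1-benzyl-1H-1,2,3-triazol-4-yl gives a 1.2-fold higher number from compound 1 to compound 4 (0.07 log units; within the scatter), so the number does not move beyond the scatter. This exchange removes the amide and its six-membered non-aromatic ring and brings in a five-membered aromatic ring and a six-membered aromatic ring of carbon only, which shows that even a group this different on this saturated chain carbon need not change the reading. Nothing measured here offers an explanation for this result.

Still open, as far as these compounds go, is what an amine or a carboxylic acid in this place would do, and whether a longer chain carrying the triazole would read the same. From the compounds shown here alone, all four compounds share the core of compound 1, so the effect of changes within that core also remains unknown.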